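Swapping a naphthyl amide for a dimethylphenyl amide

A few compounds are considered here, and "the series" means these few. Any claim that something is new, unique, unknown or untested is made for them only; others in the source may bear on it.

Measured compounds:
compound 1 `O=C(CN(Cc1ccc(C(=O)NO)cc1)C(=O)c1cccc2ccccc12)NCc1ccccc1` — 87 mL.min-1.g-1
compound 2 `CNC(=O)CN(Cc1ccc(C(=O)NO)cc1)C(=O)c1ccc(C(C)C)cc1` — 6 mL.min-1.g-1

In an ADME assay on microsomes from liver (Mus musculus) for metabolic stability, read by LC-MS, with a stated time of 40 min (a lower number here means slower removal, a higher number faster removal of the compound), compound 1 gives 87 mL.min-1.g-1, the higher of the two numbers recorded; compound 2 gives 6 mL.min-1.g-1, and the two values lie well beyond the scatter of each other. Within the data shown here, compound 2 differs from compound 1 in more than one place, so no single step between them can be read off.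

Compound 3 `Cc1ccc(C(=O)N(CC(=O)NCc2ccccc2)Cc2ccc(C(=O)NO)cc2)c(C)c1` has not yet been measured in this assay. It differs from compound 1 in one place: 2,4-dimethylphenyl in place of naphthalen-1-yl on a carbonyl carbon. The change removes two fused rings and puts in a smaller, single-ring group with two methyls, while the rest of the molecule is kept.

Compound 3 is expected to show a modest step down from compound 1, a 1.7-fold lower number from compound 1 to compound 3 (0.24 log units; within the scatter), which may not reach beyond the scatter. The intrinsic clearance of compound 3 is estimated at 50 mL.min-1.g-1, with a range from 20 mL.min-1.g-1 to 120 mL.min-1.g-1.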

Compound 3, intrinsic clearance in microsomes: 38 mL.min-1.g-1
For compound 3 the middle estimate is 1.3-fold (0.12 log units) above the measured one; the range from low to high includes it.
By their numbers in this assay, from the lowest: compound 2; then compound 3; then compound 1.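

In this assay, among these compounds, the one-place change on the carbonyl carbon gives the first step that can be read at this position: 2,4-dimethylphenyl in place of naphthalen-1-yl gives a 2.3-fold lower number from compound 1 to compound 3 (0.36 log units; beyond the scatter). With the rest of the molecule kept, this position alone therefore moves the intrinsic clearance beyond the scatter, though the step is modest and compound 3 still gives 38 mL.min-1.g-1. Nothing available explains why the number falls with this change.

The swap removes one of the two aromatic rings and adds two methyls at once, so these compounds cannot separate the two changes. An unsubstituted phenyl, a 4-methylphenyl or a pyridine ring on the same carbonyl carbon would be the kind of group to tell them apart.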